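A few compounds are considered here, and "the series" means these few. Any claim that something is new, unique, unknown or untested is made for them only; others in the source may bear on it.

Measured values in an ADME assay on microsomes from liver (Homo sapiens) for metabolic stability; on this read-out lower numbers stand for slow clearance and higher numbers for fast clearance:

Compound 1 `CNC(=O)c1sc(N2CC3CC2(CNC(=O)c2c[nH]c4ncccc24)C3)nc1C(F)(F)F`: 200 mL.min-1.g-1
Compound 2 `CNC(=O)c1sc(N2CC3CC2(CNC(=O)c2c[nH]c4ncc(C)cc24)C3)nc1C(F)(F)F`: > 270 mL.min-1.g-1

The result for compound 2 is only a limit and not a number, and compound 2 stands at the limit of > 270 mL.min-1.g-1 in this assay, at which 1 of the 2 values shown sits. Compound 3 `CNC(=O)c1sc(N2CC3CC2(CNC(=O)c2c[nH]c4ncc(Cl)cc24)C3)nc1C(F)(F)F` has chloro in place of methyl on an aromatic carbon. Among the compounds with values here, no measured step covers this exchange directly. The nearest measured change, methyl in place of hydrogen on the same aromatic carbon, is an at least 1.3-fold higher number from compound 1 to compound 2 (0.13 log units; that floor lies within the scatter). On that basis, no step beyond the scatter is expected in this assay. Within the data shown here, the expectation also rests on compound 1 at 200 mL.min-1.g-1, the only exact value available. The estimated step is an at least 1.3-fold lower number from compound 2 to compound 3 (0.13 log units; that floor lies within the scatter). Compound 3 is expected at 200 mL.min-1.g-1, with an estimated range from 100 mL.min-1.g-1 to 300 mL.min-1.g-1.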

Compound 3, intrinsic clearance in microsomes: > 300 mL.min-1.g-1
Compound 3 was reported as a limit; the forecaster's own chance of this, stated with the estimate: 25%; at least 1.5-fold (0.17 log units) between middle value and limit.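

In this assay, compound 3 returns a limit and not a number: the limit of > 300 mL.min-1.g-1 in this assay, at which 1 of the 3 values shown sits.

Chloro in place of hydrogen on this aromatic carbon gives an at least 1.5-fold higher number from compound 1 to compound 3 (0.17 log units; that floor lies within the scatter); neither methyl nor chloro on this carbon gives a lower number than hydrogen does in compound 1. The exchange of methyl for chloro cannot be read, as the results for compound 2 and compound 3 are both limits.

From the compounds shown here alone, how far compound 2 and compound 3 lie past their limits stays open, and so does the order of methyl and chloro at this position. Also open, going by these compounds, is whether an amine, a methoxy group or a nitrile on the same carbon would give a number lower than that of compound 1 at 200 mL.min-1.g-1.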